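The source may report more compounds than this note shows. Statements on the series, on what has been measured and on what is new or still open speak of the compounds shown alone.

Compound 1 `O=S(=O)(/C=C/c1ccc(Cl)cc1)Cc1ccc(Nc2ncnc3ccccc23)cc1`, compound 2 `O=S(=O)(/C=C/c1ccc(O)cc1)Cc1ccc(Nc2ncnc3ccccc23)cc1` and compound 3 `O=S(=O)(/C=C/c1ccc(Cl)cc1)Cc1ccc(Nc2ncnc3ccc(Br)cc23)cc1` share a core and differ only at two outer positions. In a functional assay on MCF7 cells (Homo sapiens) (a higher number here means a weaker inhibitor of growth, a lower number a stronger inhibitor of growth), compound 1 gives 52000 nM, compound 2 gives 100000 nM and compound 3 gives 46000 nM. The change from compound 1 to compound 2 is hydroxy in place of chloro on an aromatic carbon, and it made a step of a 1.9-fold higher number from compound 1 to compound 2 (0.28 log units; within the scatter). The two cores differ by bromo in place of hydrogen on an aromatic carbon, which gave a 1.1-fold lower number from compound 1 to compound 3 (0.05 log units; within the scatter).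

Compound 4 `O=S(=O)(/C=C/c1ccc(O)cc1)Cc1ccc(Nc2ncnc3ccc(Br)cc23)cc1` has not yet been tested in this assay. Its change from compound 3 is hydroxy in place of chloro on an aromatic carbon, the same change as from compound 1 to compound 2, at a place described in exactly the same words. The expectation for compound 4 therefore rests on that one earlier step: a similar step is expected from compound 3 to compound 4, namely a 1.9-fold higher number from compound 3 to compound 4 (0.28 log units; within the scatter), because the same change in compound 1 gave a 1.9-fold higher number from compound 1 to compound 2 (0.28 log units; within the scatter). For the measured compounds named here, on that basis compound 4 is estimated at 87000 nM, with a likely range from 45000 nM to 170000 nM, the width reflecting that only one example of this change is known.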

Compound 4, concentration for 50% growth inhibition: 32000 nM
Beside the measured number, compound 4's estimate is 2.7-fold (0.43 log units) above it; measured number below the stated range.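

In this assay, hydroxy in place of chloro did not carry over cleanly from one core to the other: on the core bearing bromo it gave a 1.4-fold lower number from compound 3 to compound 4 (0.16 log units; within the scatter), and set against the earlier step the two disagree: the same change on two cores in this assay, a 1.9-fold higher number (0.28 log units; within the scatter) from compound 1 to compound 2 and a 1.4-fold lower number (0.16 log units; within the scatter) from compound 3 to compound 4, 2.8-fold (0.44 log units) apart, beyond the scatter of two such steps The bromo change shifts in the same way, giving a modest step of a 3.1-fold lower number from compound 2 to compound 4 (0.49 log units; beyond the scatter) when hydroxy is present, which differs from its step when chloro is present: the same change on two cores in this assay, a 1.1-fold lower number (0.05 log units; within the scatter) from compound 1 to compound 3 and a 3.1-fold lower number (0.49 log units; beyond the scatter) from compound 2 to compound 4, 2.8-fold (0.44 log units) apart, beyond the scatter of two such steps So in these four compounds the effect of each change depends on the group at the other position, and a step seen on one core is a poor guide to the other, but this rests on a single pair per comparison and does not show why the steps differ.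

As far as these compounds go, it remains open whether this dependence extends to other groups in place of chloro, such as an amine or a carboxylic acid. From the compounds shown here alone, it also remains open whether it would hold with fluoro or a methyl group in place of bromo.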